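Moving a Methoxy Group Along the Benzyl Ring

The source may hold more compounds than are shown below. What is called first, only, known or untested is meant among the compounds shown, and "the series" means these compounds.

The measured compounds:
Compound 1, `Nc1ncnc2c1nc(NCCCc1ccccc1)n2[C@@H]1O[C@H](CO)[C@@H](O)[C@H]1O`, in an assay on COS-7 cells for inhibition of sodium/nucleoside cotransporter 2 (Homo sapiens), read by scintillation counting, in the presence of a further agent that is not named here (on this read-out lower numbers stand for stronger inhibition and higher numbers for weaker inhibition), gives 536000 nM.
Compound 2, `Cc1ccccc1CNc1nc2c(N)ncnc2n1[C@@H]1O[C@H](CO)[C@@H](O)[C@H]1O`, in this assay gives 65000 nM.
Compound 3, `COc1ccccc1CNc1nc2c(N)ncnc2n1[C@@H]1O[C@H](CO)[C@@H](O)[C@H]1O`, in this assay gives only a limit, > 100000 nM.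

Compound 3 therefore has no exact number: its value is a limit, (the limit of > 100000 nM in this assay, at which 1 of the 3 values shown sits), so it sits among the weakest of the three but at an unknown distance from compound 2. The step of an at least 1.5-fold higher number from compound 2 to compound 3 (0.18 log units; that floor lies within the scatter) is likewise only a floor. The clearest step is an 8.2-fold lower number from compound 1 to compound 2 (0.92 log units; beyond the scatter), while a step that the limit leaves unreadable from compound 1 to compound 3 cannot be read.

Compound 4, `COc1cccc(CNc2nc3c(N)ncnc3n2[C@@H]2O[C@H](CO)[C@@H](O)[C@H]2O)c1`, has not been measured. It differs from compound 3 by 3-methoxyphenyl in place of 2-methoxyphenyl on a saturated chain carbon bound to a nitrogen on an aromatic ring. Among the compounds with values here, none of the measured steps changes the position of a group on the phenyl ring, so none speaks directly to this move; the measured steps only show that the benzyl series around compound 2 and compound 3 stays weak. The step of an at least 1.1-fold lower number from compound 3 to compound 4 (0.04 log units; that floor lies within the scatter) is expected to be small or undetectable. Compound 4 is estimated at 90000 nM in this assay, with a plausible range from 30000 nM to 300000 nM, and a real chance that only a limit is reported again.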

Compound 4, half-maximal inhibitory concentration: 13000 nM
Compound 4: the middle estimate sits 6.9-fold (0.84 log units) above what was measured; the whole stated range lies above it.
By their numbers in this assay, from the lowest: compound 4; then compound 2; then compound 1.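

Moving the methoxy group from 2-methoxybenzyl to 3-methoxybenzyl, with the same atoms joined differently, is the only change of ring position among these compounds, and in this assay it gives an at least 7.6-fold lower number from compound 3 to compound 4 (0.88 log units; beyond the scatter). Within the data shown here, that step is only a floor, since compound 3 carries a limit rather than a number: the limit of > 100000 nM in this assay, at which 1 of the 4 values shown sits. Compared with the exact values, the move to the 3-methoxyphenyl group gives a 5.0-fold lower number from compound 2 to compound 4 (0.70 log units; beyond the scatter), a step that changes both the group and its place on the ring, and a 41-fold lower number from compound 1 to compound 4 (1.62 log units; beyond the scatter), so compound 4 is the strongest inhibitor of the four and the benzyl series is not uniformly weak, as the earlier compounds had suggested.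

The compounds shown leave open whether this gain needs the methoxy group or comes from the new ring position alone, a question that a methyl group moved in the same way would help to settle. They also leave open whether a hydroxyl, an amine or a chlorine in place of the methoxy group would keep this level, and how the 3-methoxyphenyl group would behave on a longer chain like that of compound 1.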